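A few compounds are considered here, and "the series" means these few. Any claim that something is new, unique, unknown or untested is made for them only; others in the source may bear on it.

Measured compounds in a functional assay on HepG2 cells (Homo sapiens) for antiproliferative activity, read by MTT assay, with a stated time of 48 h; a higher number here means a weaker inhibitor, a lower number a stronger inhibitor:
- compound 1 `CCCCCCOc1ccc(C(=O)/C=C/c2c(/C=C/c3ccc(OC)cc3)cc(OC)cc2OC)cc1` gives 16.2 ug/mL
- compound 2 `COc1ccc(/C=C/c2cc(OC)cc(OC)c2/C=C/C(=O)c2ccc(C(F)(F)F)cc2)cc1` gives 18.7 ug/mL
- compound 3 `COc1ccc(/C=C/c2cc(OC)cc(OC)c2/C=C/C(=O)c2ccccc2)cc1` gives 6.8 ug/mL

Among these three, compound 1 stands with the second highest number, close to compound 2 (a 1.2-fold higher number from compound 1 to compound 2 (0.06 log units; within the scatter)) and clearly apart from compound 3 (a 2.4-fold lower number from compound 1 to compound 3 (0.38 log units; beyond the scatter)). Going by the values given here, the only step that reaches beyond the scatter is the one that removes a group from the aromatic carbon: both a 2.4-fold lower number from compound 1 to compound 3 (0.38 log units; beyond the scatter) and a 2.8-fold lower number from compound 2 to compound 3 (0.44 log units; beyond the scatter) lower the number when hydrogen takes the place of a substituent there.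

Compound 4 `COc1ccc(/C=C/c2cc(OC)cc(OC)c2/C=C/C(=O)c2ccc(OC)cc2)cc1` differs from compound 1 in one place: hydrogen in place of pentyl on a saturated chain carbon bound to an oxygen on an aromatic ring. Read one bond further out, hexyloxy becomes methoxy, so compound 4 keeps an oxygen substituent on that aromatic carbon but loses most of the chain. Among the compounds with values here, no measured step removes only part of the chain, so the bearing of the steps from compound 1 to compound 3 and compound 2 to compound 3 is indirect. A modest lowering is expected, sized as a 1.6-fold lower number from compound 1 to compound 4 (0.21 log units; within the scatter), landing between the numbers of compound 1 and compound 3. Compound 4 is therefore estimated at 10 ug/mL in this assay, with a range from 5 ug/mL to 20 ug/mL.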

Compound 4, half-maximal inhibitory concentration: 4.9 ug/mL
Estimate against measurement, compound 4: 2.0-fold (0.31 log units) above; the whole stated range lies above it.
By their numbers in this assay, from the lowest: compounds 4 and 3 (each within the scatter of the next); then compounds 1 and 2 (each within the scatter of the next).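

In this assay, cutting hexyloxy down to methoxy keeps the oxygen on the aromatic carbon yet gives a 3.3-fold lower number from compound 1 to compound 4 (0.52 log units; beyond the scatter), so the higher number of compound 1 goes with the length of the chain and not with the oxygen alone. Going by these compounds alone, the earlier compounds showed only that two groups, hexyloxy and trifluoromethyl, gave higher numbers than hydrogen, whereas methoxy does not separate from hydrogen, with a 1.4-fold lower number from compound 3 to compound 4 (0.14 log units; within the scatter), and it differs clearly from trifluoromethyl, with a 3.8-fold lower number from compound 2 to compound 4 (0.58 log units; beyond the scatter), so a substituent here does not by itself raise the number. Nothing measured here explains these differences.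

On these data alone, how the number moves with chains short of hexyloxy, such as ethoxy or butoxy, remains open. So does whether an amine or a carboxylic acid on this aromatic carbon would group with methoxy and hydrogen or with hexyloxy and trifluoromethyl.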